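Ring expansion on the urea nitrogen of compound 1

A few compounds are considered here, and "the series" means these few. Any claim that something is new, unique, unknown or untested is made for them only; others in the source may bear on it.

Measured so far:
- compound 1 `Cc1cc(C)c(NC(=O)N(Cc2cccc(-c3cc[nH]n3)c2)C2CCCCC2)c(C)c1`: 0.12 mg/kg
- compound 2 `COc1cccc(CN(Cc2cccc(-c3cc[nH]n3)c2)C(=O)Nc2c(SC)cc(C)nc2SC)c1`: > 0.1 mg/kg
- compound 3 `O=C(Nc1c(F)cc(F)cc1F)N(Cc1ccc(-c2ccccn2)cc1)C1CCCCCC1`: > 1 mg/kg

Among the measured compounds shown here, in a functional assay on a cell-free system (plasma) with sterol O-acyltransferase, Soat (Rattus norvegicus) as the target (a lower number here means that less compound is needed, a higher number that more compound is needed for the effect), compound 1 gives 0.12 mg/kg and is the only compound of the three with a number rather than a limit. Compound 2 shows only a limit of this assay, > 0.1 mg/kg, as stated in the limit of > 0.1 mg/kg in this assay, at which 1 of the 3 values shown sits. Compound 3 likewise shows only a limit, > 1 mg/kg, as stated in the limit of > 1 mg/kg in this assay, at which 1 of the 3 values shown sits. For the measured compounds named here, the two limits cannot be set against the number for compound 1, so no measured step between these three compounds is available.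

Compound 4 `Cc1cc(C)c(NC(=O)N(Cc2cccc(-c3cc[nH]n3)c2)C2CCCCCC2)c(C)c1` differs from compound 1 in one place: cycloheptyl in place of cyclohexyl on an amide-type nitrogen. No comparable change is measured in this series, so the expected step from compound 1 to compound 4, a 1.7-fold higher number from compound 1 to compound 4 (0.22 log units; within the scatter), is small and within the usual scatter, with a modest weakening the more likely direction if any. Compound 4 is therefore estimated at 0.2 mg/kg in this assay, with a range from 0.08 mg/kg to 0.6 mg/kg.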

Compound 4, dose for half-maximal effect: 0.097 mg/kg
Compound 4: middle estimate off by 2.1-fold (0.31 log units), on the high side; measured number inside the range.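

In this assay, cycloheptyl in place of cyclohexyl on an amide-type nitrogen gives a 1.2-fold lower number from compound 1 to compound 4 (0.09 log units; within the scatter). Among the compounds shown here, this is the only measured step so far, and it shows that this position accepts the seven-membered ring as well as the six-membered one, with no difference that can be told from the scatter of the assay. Nothing at hand bears on why the two rings read alike.

On these data alone, only these two carbon rings have a number at this place on the shared core, so the outcome with a smaller ring such as cyclopentyl, an open hexyl chain, or a ring carrying an amine or a carboxylic acid remains open. As far as these compounds go, whether the two rings also read alike when another part of the core is changed remains open as well.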